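The source may report more compounds than this note shows. Statements on the series, on what has been measured and on what is new or still open speak of the compounds shown alone.

Measured compounds: compound 1 `CC#C[C@H]1CN(S(=O)(=O)c2ccc(N)nc2)CCN1c1ncc(C(C)(O)C(F)(F)F)s1` and compound 2 `CC#C[C@H]1CN(S(=O)(=O)c2ccc(N)nc2)CCN1c1ccc(S(=O)(=O)NCC2CC2)cc1`.

In an assay on cells (Hepatocyte) for inhibition of glucokinase regulatory protein (Mus musculus), with stated times of 20 min and 40 min (a higher number here means that more compound is needed for the effect, a lower number that less compound is needed), compound 1 gives > 12500 nM, which is a limit of the assay and not a number, and the limit of > 12500 nM in this assay, at which 1 of the 2 values shown sits, records it as such. In this assay compound 2 gives 271 nM. Among the compounds with values here, this is the only full number; the value for compound 1 is a limit only. Within the data shown here, no step between two measured compounds is available, so nothing measured tells how a change on the shared core of compound 2 moves the read-out.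

Compound 3 `CC#C[C@H]1CN(S(=O)(=O)c2ccc(N)nc2)CCN1c1ccc([C@](O)(CO)C(F)(F)F)cc1` differs from compound 2 by 1,2-dihydroxy-1-(trifluoromethyl)ethyl in place of (cyclopropylmethyl)sulfamoyl on an aromatic carbon. Among the measured compounds shown here, since no measured step covers a change of this kind, the expectation rests on compound 2 alone, and the step is taken as modest and possibly favourable rather than none. Compound 3 is therefore expected to give 60 nM in this assay, between 10 nM and 400 nM, which means an expected step of a 4.5-fold lower number from compound 2 to compound 3 (0.65 log units; beyond the scatter).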

Compound 3, half-maximal effective concentration: 98 nM
Compound 3: the middle estimate sits 1.6-fold (0.21 log units) below what was measured; the measured number falls inside the stated range.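

In this assay, the exchange of (cyclopropylmethyl)sulfamoyl for 1,2-dihydroxy-1-(trifluoromethyl)ethyl on this aromatic carbon, para to a large group, gives a 2.8-fold lower number from compound 2 to compound 3 (0.44 log units; beyond the scatter). Within the data shown here, this is the first measured step at this position, and it shows that the sulfamoyl group is not needed for a full number here: an open-chain group of the same heavy-atom count, with no sulfur, no nitrogen and no ring, serves at least as well. The data shown do not account for the size of this step.

From the compounds shown here alone, it remains open which part of the entering group carries the step, for instance how a plain trifluoromethyl group, a single hydroxymethyl group or a carboxylic acid would read at this position. Going by these compounds, the opposite configuration at the defined stereocentre of compound 3 is also open.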